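Cyclobutylsulfonyl to cyclobutylsulfamoyl on the aryl sulfone

The compounds below may be only part of what the source reports. "The series", "measured", "known", "first", "only" and "open" are said of these compounds alone.

Measured so far:
compound 1 `CC(C)c1noc(N2CCN(C(=O)[C@@H]3CCCN(S(=O)(=O)c4ccc(S(=O)(=O)C5CCC5)cc4)C3)CC2)n1` — > 10000 nM
compound 2 `CCOC(=O)[C@@H]1CCC[C@@H](S(=O)(=O)c2ccc(S(=O)(=O)N(CC)CC)cc2)C1` — > 10000 nM

In a functional assay on MIA PaCa-2 cells (Homo sapiens) for inhibition, read by MTT assay, with a stated time of 3 days (on this read-out higher numbers stand for weaker inhibition and lower numbers for stronger inhibition), compound 1 gives > 10000 nM, which is a limit of the assay and not a number. Compound 2 likewise gives only a limit, > 10000 nM. Where compound 1 stands on the numbers shown is therefore fixed only by the limit of > 10000 nM in this assay, at which 2 of the 2 values shown sit; no step between two measured compounds exists, so no measured size of change is known for this series.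

Compound 3 `CC(C)c1noc(N2CCN(C(=O)[C@@H]3CCCN(S(=O)(=O)c4ccc(S(=O)(=O)NC5CCC5)cc4)C3)CC2)n1` differs from compound 1 by cyclobutylamino in place of cyclobutyl on a sulfonyl sulfur, on a sulfonyl sulfur whose other neighbour is an aromatic carbon. With both shown values at the limit, the step from compound 1 to compound 3 is expected to be none beyond the scatter, most likely again reported as a limit. The expected step is a step that the limit leaves unreadable from compound 1 to compound 3. Compound 3 is estimated at 15000 nM in this assay, with a range of 4000 nM to 60000 nM.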

Compound 3, half-maximal inhibitory concentration: > 10000 nM
Compound 3 ended at the assay's limit; the forecaster's own chance of this, stated with the estimate: 80%; the middle value does not contradict the limit.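

In this assay compound 3 gives > 10000 nM, a limit of the assay and not a number. Among the compounds shown here, compound 1 also stands at a limit, so no step between compound 1 and compound 3 can be read: the limit of > 10000 nM in this assay, at which 3 of the 3 values shown sit. The compounds shown leave open whether cyclobutylamino in place of cyclobutyl changes inhibition at all.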